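From ethoxymethyl to isopropoxymethyl on the shared core

The source may hold more compounds than are shown below. What is called first, only, known or untested is meant among the compounds shown, and "the series" means these compounds.

Measured so far in a physicochemical assay for solubility, at pH 7.4; a higher number here means a more soluble compound, a lower number a less soluble compound:
compound 1 `COCc1nc(Nc2ccc(C(F)(F)F)cc2)c2ccc(-c3ncccc3C(F)(F)F)cc2n1` gives 0.2 ug/mL
compound 2 `CCOCc1nc(Nc2ccc(C(F)(F)F)cc2)c2ccc(-c3ncccc3C(F)(F)F)cc2n1` gives 0.6 ug/mL

Compound 2 holds the higher of these two numbers. Compound 3 `CC(C)OCc1nc(Nc2ccc(C(F)(F)F)cc2)c2ccc(-c3ncccc3C(F)(F)F)cc2n1` differs from it by methyl in place of hydrogen on a saturated chain carbon bound to an oxygen on a saturated carbon and a saturated chain carbon and turns ethoxymethyl into isopropoxymethyl. For the measured compounds named here, only one measured step bears on this change: a 3.0-fold higher number from compound 1 to compound 2 (0.48 log units; beyond the scatter), which also placed methyl for hydrogen on a saturated chain carbon. With that single modest rise as the guide, a small further rise in this assay is expected, possibly none beyond the scatter. The expected step is a 1.5-fold higher number from compound 2 to compound 3 (0.18 log units; within the scatter) and no more than an estimate. Compound 3 is expected at 0.9 ug/mL with an estimated range of 0.3 ug/mL to 2.5 ug/mL.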

Compound 3, solubility: 0.04 ug/mL
Beside the measured number, compound 3's estimate is 23-fold (1.35 log units) above it, outside the stated range (below it).
By their numbers in this assay, from the lowest: compound 3; then compound 1; then compound 2.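

In this assay, the same placing of methyl for hydrogen that earlier went with a rise now gives a 15-fold lower number from compound 2 to compound 3 (1.18 log units; beyond the scatter), so the effect of this change at a saturated chain carbon bound to an oxygen does not carry over from one step to the next. Isopropyl in place of methyl on the oxygen gives a 5.0-fold lower number from compound 1 to compound 3 (0.70 log units; beyond the scatter), so the three compounds follow no steady order from methyl through ethyl to isopropyl. Nothing available here explains this reversal.

The compounds shown leave open whether the fall belongs to branching or to chain size alone. They also leave open how a longer chain such as propoxymethyl, or an amine on the ether chain, would compare.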